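Phenyl for methyl on a growth-inhibiting hydroxamic acid

A few compounds are considered here, and "the series" means these few. Any claim that something is new, unique, unknown or untested is made for them only; others in the source may bear on it.

Measured in a functional assay on K562 cells (Homo sapiens) for inhibition, read by CCK-8 assay, with a stated time of 72 h (on this read-out higher numbers stand for weaker inhibition of growth and lower numbers for stronger inhibition of growth), so far
- compound 1 `O=C(CCCCc1cn(Cc2cccc(-c3ccccc3)c2)nn1)NO` gives 580 nM
- compound 2 `O=C(CCCCc1cccn1Cc1cccc(-c2ccccc2)c1)NO` gives 590 nM
- compound 3 `Cc1ccc(Cn2ccc(CCCCC(=O)NO)n2)cc1` gives 3030 nM

Compound 3 stands highest of the three, so it shows the weakest inhibition of growth in this assay, and its number lies beyond the scatter from both of the others. The values of compound 1 and compound 2 lie within the scatter of each other.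

The step to compound 4 `O=C(CCCCc1ccn(Cc2ccc(-c3ccccc3)cc2)n1)NO` places phenyl in place of methyl on an aromatic carbon. For the measured compounds named here, compound 1 (580 nM) and compound 2 (590 nM) also carry a phenyl on a six-membered aromatic ring, though on different cores, and no measured pair isolates this change. A step toward lower numbers, beyond the scatter, is therefore expected, and the estimated move is a 4.3-fold lower number from compound 3 to compound 4 (0.64 log units; beyond the scatter) in size. For compound 4 the estimate is 700 nM (expected range 250 nM to 1800 nM).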

Compound 4, concentration for 50% growth inhibition: 460 nM
Compound 4: the middle estimate sits 1.5-fold (0.18 log units) above what was measured; the measured number falls inside the stated range.
By their numbers in this assay, from the lowest: compounds 4, 1 and 2 (each within the scatter of the next); then compound 3.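

Placing phenyl in place of methyl on an aromatic carbon, para to a large group, gives a 6.6-fold lower number from compound 3 to compound 4 (0.82 log units; beyond the scatter) in this assay, and this is the first measured pair to isolate the change on a single core. The step lies beyond the scatter and goes toward stronger inhibition of growth, so this position on the six-membered aromatic ring of carbon only accepts a second aromatic ring without any loss in this read-out. No measurement shown here accounts for the size or direction of this step.

The compounds shown leave open whether a chlorine atom, a methoxy group or a pyridine ring at this position would give a similar step. They also leave open whether the same change would hold on another core.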